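The compounds below may be only part of what the source reports. "The series", "measured", "known", "first", "only" and "open" are said of these compounds alone.

Series notes. In an assay on CHO cells for displacement of a labelled ligand from D(4) dopamine receptor (Homo sapiens), read by radioligand binding (on this read-out higher numbers stand for weaker inhibition and lower numbers for stronger inhibition), compound 1 `COc1ccccc1N1CCN(CCCNC(=O)NN(Cc2ccc(F)cc2)c2ccc(F)cc2)CC1` gives 4.6 nM, the lowest of the three numbers at hand, though not separated from all of them. Compound 3 `COc1ccccc1N1CCN(CCCNC(=O)NN(Cc2ccc(-c3ccccc3)cc2)c2ccc(F)cc2)CC1` gives 5.9 nM in this assay and lies within the scatter of compound 1; compound 2 `COc1ccccc1N1CCN(CCCNC(=O)NN(Cc2ccc(C#N)cc2)c2ccc(F)cc2)CC1` gives 15 nM and lies further off.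

The step to compound 4 `COc1ccc(N(Cc2ccc(F)cc2)NC(=O)NCCCN2CCN(c3ccccc3OC)CC2)cc1` is methoxy in place of fluoro on an aromatic carbon; the same difference cut one bond further out reads 4-fluorophenyl to 4-methoxyphenyl.

Two measured steps alter the same aromatic carbon of the six-membered aromatic ring of carbon only. a 3.3-fold higher number from compound 1 to compound 2 (0.51 log units; beyond the scatter) shows a modest loss for cyano in place of fluoro. a 1.3-fold higher number from compound 1 to compound 3 (0.11 log units; within the scatter) shows phenyl in place of fluoro carried without a change beyond the scatter. Nothing measured carries a methoxy at this carbon, so the expectation rests on these two: both replacements of the fluoro were tolerated, one without loss, one with a modest loss. For methoxy a step within or close to the scatter is expected in this assay, if anything towards a slightly higher number, and a 1.4-fold higher number from compound 1 to compound 4 (0.15 log units; within the scatter) is the step the estimate implies. Compound 4 is therefore estimated at 6.5 nM in this assay, with a range from 2.5 nM to 17 nM.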

Compound 4, inhibition constant: 2.9 nM
Beside the measured number, compound 4's estimate is 2.2-fold (0.35 log units) above it, within the range that was stated.
By their numbers in this assay, from the lowest: compounds 4, 1 and 3 (each within the scatter of the next, the first and the last beyond it); then compound 2.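

In this assay the change from 4-fluorophenyl to 4-methoxyphenyl gives a 1.6-fold lower number from compound 1 to compound 4 (0.20 log units; within the scatter) and so shows that this fluoro can give way to methoxy without a step beyond the scatter. Among the compounds shown here, this is the first reading on this group: compounds 2 and 3 keep the 4-fluorophenyl and change the other fluoro of compound 1, so their steps describe a different aromatic carbon. For the compounds shown here, compound 4 differs from compounds 2 and 3 in two places, which leaves compound 1 as its only direct comparison, and methoxy as the only replacement read at this carbon.

Going by these compounds, it remains open whether an amine, a hydroxy group or a carboxylic acid on this aromatic carbon would also stay within the scatter of compound 1, and whether a longer chain such as ethoxy would follow methoxy. Also open, on these data alone, is whether cyano or phenyl here would repeat the steps of a 3.3-fold higher number from compound 1 to compound 2 (0.51 log units; beyond the scatter) and a 1.3-fold higher number from compound 1 to compound 3 (0.11 log units; within the scatter) seen at the other fluoro. Nothing on hand offers an explanation for the reading at this carbon.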